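The compounds below may be only part of what the source reports. "The series", "measured", "known", "first", "only" and "open" are said of these compounds alone.

Measured so far in a functional assay (aorta) with Rattus norvegicus as the target; a higher number here means that more compound is needed for the effect, a lower number that less compound is needed:
Compound 1 `COc1ccc(-c2nc(/N=C(\N)N3CCOCC3)sc2-c2ccc(OC)cc2)cc1` gives 66 uM.
Compound 2 `COc1ccc(-c2nc(CNC(C)=O)sc2-c2ccc(OC)cc2)cc1` gives 8.1 uM.
Compound 3 `COc1ccc(-c2nc(CNC(=O)NC(C)C)sc2-c2ccc(OC)cc2)cc1` gives 5.7 uM.

Compound 3 stands at the lowest of the three numbers in this assay. The nearest is compound 2, with a 1.4-fold lower number from compound 2 to compound 3 (0.15 log units; within the scatter), a gap within the scatter, so the two cannot be placed in order. The furthest is compound 1, with a 12-fold lower number from compound 1 to compound 3 (1.06 log units; beyond the scatter); the related step to compound 2 was an 8.1-fold lower number from compound 1 to compound 2 (0.91 log units; beyond the scatter).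

Compound 4 `COc1ccc(-c2nc(C3=CCN(C)CC3)sc2-c2ccc(OC)cc2)cc1` is the next compound. How it differs from compound 3: a group of 7 heavy atoms (6 carbon, 1 nitrogen; one six-membered non-aromatic ring with 1 hetero atom) in place of a group of 8 heavy atoms (5 carbon, 2 nitrogen, 1 oxygen; no ring), on an aromatic carbon

Both measured steps change the same position on the shared core, and both ran from the ring-bearing group of compound 1 to groups without a ring in compounds 2 and 3, ending at lower numbers. Within the data shown here, no measured step exchanges a group without a ring for one with a ring, and the ring of compound 4 appears in no measured compound. Among the measured compounds shown here, the single ring-bearing group measured, in compound 1, carries the highest number. For the measured compounds named here, with no direct precedent, the expected step in this assay is a 2.6-fold higher number from compound 3 to compound 4 (0.42 log units; beyond the scatter), toward a higher number, with wide uncertainty. For compound 4 the estimate is 15 uM, range 4 uM to 60 uM.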

Compound 4, concentration for half-maximal effect: 5.9 uM
Compound 4: middle estimate off by 2.5-fold (0.41 log units), on the high side, within the range that was stated.
By their numbers in this assay, from the lowest: compounds 3, 4 and 2 (each within the scatter of the next); then compound 1.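

In this assay the position on the aromatic carbon tolerates a six-membered non-aromatic ring with 1 hetero atom: a 1.0-fold higher number from compound 3 to compound 4 (0.01 log units; within the scatter) and a 1.4-fold lower number from compound 2 to compound 4 (0.14 log units; within the scatter) leave compounds 2, 3 and 4 in no readable order, so the group with 0 hydrogen-bond donors cannot be told apart from ((isopropylcarbamoyl)amino)methyl with its 2 hydrogen-bond donors. With an 11-fold lower number from compound 1 to compound 4 (1.05 log units; beyond the scatter) between two ring-bearing groups, the high number of compound 1 can no longer be tied to the presence of a ring at this position, since compound 4 carries a ring and still sits with the two ring-free compounds. Nothing in hand accounts for why such different groups give indistinguishable numbers here, so this stands as an observation only.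

Open, from the compounds shown here alone, is whether the ring itself matters at all, as a simple dimethylaminomethyl group or a saturated N-methylpiperidine in the same place would show. Also open, going by these compounds, is whether a carboxylic acid or a longer chain at this position would stay with compounds 2, 3 and 4 or move toward compound 1.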